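A few compounds are considered here, and "the series" means these few. Any claim that something is new, unique, unknown or untested is made for them only; others in the source may bear on it.

Measured compounds in an ADME assay on HeLa cells (Homo sapiens) for cytotoxicity, read by ATP content, with a stated time of 3 days; a lower number here means that less compound is tolerated, a higher number that more compound is tolerated:
- compound 1 `COc1ccc(-n2c(=O)n(Cc3cc4cc(Cl)ccc4n3CCCC#N)c3cnccc32)cc1`: > 50000 nM
- compound 2 `O=c1n(Cc2cc3cnccc3n2CCCCO)c2cnccc2n1C1CC1`: > 100000 nM
- compound 3 `O=c1n(Cc2cc3cc(Cl)ccc3n2CCCCO)c2cnccc2n1C1CC1`: > 50000 nM

None of these three values is a number. The result for compound 1 is a limit of this assay, > 50000 nM. The result for compound 2 is likewise a limit, > 100000 nM. The result for compound 3 is also a limit, > 50000 nM. Two of the results sit at the limit of > 50000 nM in this assay, at which 2 of the 3 values shown sit, and one sits at the limit of > 100000 nM in this assay, at which 1 of the 3 values shown sits. Compound 1 therefore stands where the other two stand: at a limit, with no number to rank it against them.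

Compound 4 `N#CCCCn1c(Cn2c(=O)n(-c3ccncc3F)c3ccncc32)cc2cc(Cl)ccc21` has not yet been measured in this assay. It differs from compound 1 in one place: 3-fluoropyridin-4-yl in place of 4-methoxyphenyl on an aromatic nitrogen. Within the data shown here, no step between measured compounds is available for this change, so the expectation rests on the fact that compound 1 itself shows only a limit. No shift beyond the usual scatter is expected from compound 1 to compound 4, and the step that the limit leaves unreadable from compound 1 to compound 4 is the estimate that follows. For compound 4 the expected value in this assay is 80000 nM, estimated to fall between 30000 nM and 200000 nM, most likely again as a limit rather than a number.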

Compound 4, half-maximal cytotoxic concentration: > 50000 nM
Compound 4 was reported as a limit; the forecaster's own chance of this, stated with the estimate: 85%; the middle value does not contradict the limit.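

Compound 1 and compound 4 are both reported only as limits in this assay, so no step between them can be read; both sit at the same limit: the limit of > 50000 nM in this assay, at which 3 of the 4 values shown sit.

The compounds shown leave open what effect, if any, 3-fluoropyridin-4-yl in place of 4-methoxyphenyl has on the half-maximal cytotoxic concentration.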